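The source may hold more compounds than are shown below. What is called first, only, known or untested is meant among the compounds shown, and "the series" means these compounds.

In a functional assay on FaDu cells (Homo sapiens) for antiproliferative activity, read by sulforhodamine B assay, with a stated time of 48 h (on this read-out higher numbers stand for weaker inhibition and lower numbers for stronger inhibition), compound 1 (`CCCCN(C)C(=O)CCCOc1cc(OC)c(OC)c2oc(-c3ccc(OC)cc3)c(O)c(=O)c12`) gives > 40000 nM, which is a limit of the assay and not a number. Compound 2 (`COc1ccc(-c2oc3c(OC)c(OC)cc(OCCCCCC(=O)NCc4ccccn4)c3c(=O)c2O)cc1`) gives > 40000 nM, which is also a limit. Neither compound has a number, and the data show only (the limit of > 40000 nM in this assay, at which 2 of the 2 values shown sit). Where compound 1 truly stands is therefore unknown.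

Compound 3 (`COc1ccc(-c2oc3c(OC)c(OC)cc(OC(C)CN(C)C)c3c(=O)c2O)cc1`) keeps the shared core but has not yet been measured. Its difference from compound 1 is 1-((dimethylamino)methyl)ethyl in place of 3-(butyl(methyl)carbamoyl)propyl on an oxygen on an aromatic ring. In words, 1-((dimethylamino)methyl)ethyl stands in place of 3-(butyl(methyl)carbamoyl)propyl on an oxygen on an aromatic ring.

Going by the values given here, only one measured step bears on this change, a step that the two limits leave unreadable from compound 1 to compound 2. It alters the same chain, but it gives no size to carry over. Compound 3 differs from both measured compounds in having no carbonyl in this chain, so its outcome cannot be read from them. A modest move toward stronger inhibition in this assay is expected, though compound 3 may well remain at a limit. The expected change is an at least 1.6-fold lower number from compound 1 to compound 3 (0.20 log units; that floor lies within the scatter). For compound 3 the estimated value is 25000 nM, with an expected range from 6000 nM to 60000 nM.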

Compound 3, half-maximal inhibitory concentration: 5410 nM
Estimate against measurement, compound 3: 4.6-fold (0.66 log units) above, outside the stated range (below it).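

In this assay, placing 1-((dimethylamino)methyl)ethyl in place of 3-(butyl(methyl)carbamoyl)propyl on an oxygen on an aromatic ring gives an at least 7.3-fold lower number from compound 1 to compound 3 (0.86 log units; beyond the scatter). This is the first readable step at this oxygen among the compounds shown, and it demonstrates that the number on the shared core can move with the group carried there. The true size of the step stays unknown and only its floor is fixed, because compound 1 carries a limit of the assay and not a number: the limit of > 40000 nM in this assay, at which 2 of the 3 values shown sit.

This single step removes the carbonyl and the butyl(methyl) amide and brings in the dimethylamino group on a branched carbon chain all at once, and the compounds shown do not separate these parts. As far as these compounds go, it also stays open whether an unbranched 2-(dimethylamino)ethyl group, or a ring amine such as piperidine carried on a carbon chain on the same oxygen, would keep, strengthen or weaken the inhibition seen with compound 3.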